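Swapping the Aryl Group on a Weakly Active Core

The compounds below may be only part of what the source reports. "The series", "measured", "known", "first", "only" and "open" are said of these compounds alone.

Compound 1 `CCOC(=O)c1cnn(-c2nc(-c3ccccc3Cl)c(C#N)c(=O)n2C)c1N` was tested in a functional assay, with a stated time of 20 min (a higher number here means a weaker inhibitor, a lower number a stronger inhibitor), where compound 1 gives 78 ug/mL. Compound 3 `CSc1nc(-c2ccc(N(C)C)cc2)c(C#N)c(=O)n1C` gives 78 ug/mL in this assay, the same number at the digits shown, and compound 2 `Cn1c(NN)nc(-c2ccc(Cl)cc2)c(C#N)c1=O` gives 44 ug/mL, a gap that stays within the usual scatter. Compound 1 and compound 3 thus share the highest of the three numbers, although all three lie close together. Compound 4 `CCOC(=O)c1cnn(-c2nc(-c3ccc(N(C)C)cc3)c(C#N)c(=O)n2C)c1N` has not yet been measured. It differs from compound 1 in one place: 4-(dimethylamino)phenyl in place of 2-chlorophenyl on an aromatic carbon. The same 4-(dimethylamino)phenyl group is present in compound 3, whose 78 ug/mL matches compound 1, so no shift beyond the scatter is anticipated. The expected step is a 1.1-fold lower number from compound 1 to compound 4 (0.05 log units; within the scatter). Compound 4 is estimated to give about 70 ug/mL, between 30 ug/mL and 160 ug/mL.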

Compound 4, half-maximal inhibitory concentration: 98 ug/mL
Compound 4: middle estimate off by 1.4-fold (0.15 log units), on the low side; low and high end bracket the measured number.
By their numbers in this assay, from the lowest: compounds 2, 1, 3 and 4 (each within the scatter of the next, the first and the last beyond it).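

In this assay, among these compounds, putting 4-(dimethylamino)phenyl on this aromatic carbon in place of 2-chlorophenyl gives a 1.3-fold higher number from compound 1 to compound 4 (0.10 log units; within the scatter) and offers the first direct comparison at this position, with the rest of the molecule held the same. These two quite different aryl groups therefore cannot be told apart here, and the shared core stays weakly active with either one. Nothing available explains this result. Still open, on these data alone, is whether a smaller or differently built group at this carbon, such as a plain phenyl, a 4-hydroxyphenyl or a pyridine ring, would give a step beyond the scatter.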